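Compound 3: hydrogen on the aromatic nitrogen

A few compounds are considered here, and "the series" means these few. Any claim that something is new, unique, unknown or untested is made for them only; others in the source may bear on it.

In a functional assay on A-375 cells (Homo sapiens) for cytotoxicity, read by MTT assay, with a stated time of 72 h (a lower number here means a stronger inhibitor, a higher number a weaker inhibitor), compound 2 `O=C1c2c[n+]([O-])c3ccccc3c2C(=O)c2c1c1ccccc1n2Cc1cn(C[C@@H](O)CO)nn1` gives 140 nM. Within the data shown here, compound 1 `O=C1c2c[n+]([O-])c3ccccc3c2C(=O)c2c1c1ccccc1n2CCCCN1CCCCC1`, the only other compound measured, gives 190 nM, so the two cannot be told apart on these numbers. Compound 3 `O=C1c2c[n+]([O-])c3ccccc3c2C(=O)c2[nH]c3ccccc3c21` keeps the shared core but places hydrogen on the aromatic nitrogen, in place of (1-(2,3-dihydroxypropyl)-1H-1,2,3-triazol-4-yl)methyl: hydrogen in place of (1-(2,3-dihydroxypropyl)-1H-1,2,3-triazol-4-yl)methyl on an aromatic nitrogen. Among the measured compounds shown here, the only measured step that bears on this is a 1.4-fold lower number from compound 1 to compound 2 (0.13 log units; within the scatter). It shows two different chains on that nitrogen giving numbers within the scatter of each other. For the measured compounds named here, no measured compound has hydrogen there, however, so the evidence is indirect and the uncertainty wide. No change beyond the scatter is therefore expected, in either direction. The expected step is a 1.2-fold higher number from compound 2 to compound 3 (0.08 log units; within the scatter). In this assay the estimate for compound 3 is 170 nM, with an estimated range of 60 nM to 500 nM.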

Compound 3, half-maximal inhibitory concentration: 660 nM
Compound 3: middle estimate off by 3.9-fold (0.59 log units), on the low side; measured number outside the range, above it.
By their numbers in this assay, from the lowest: compounds 2 and 1 (each within the scatter of the next); then compound 3.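

In this assay, replacing either chain with hydrogen on the aromatic nitrogen gives a 4.7-fold higher number from compound 2 to compound 3 (0.67 log units; beyond the scatter) and a 3.5-fold higher number from compound 1 to compound 3 (0.54 log units; beyond the scatter). The two chains had differed only within the scatter, which left open whether this position mattered at all; these steps show that it does, as both chain-bearing compounds give lower numbers than the compound with hydrogen there. Nothing shown here accounts for this difference.

On these data alone, it remains open whether a single methyl on this nitrogen would be enough to give a number like those of the two chains, or whether a longer chain is required. Also open, as far as these compounds go, is whether a chain ending in a primary amine or a carboxylic acid would do the same as the piperidine and the dihydroxypropyl triazole.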